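Carbamate nitrogen substituent: propyl to cyclobutyl

The source may report more compounds than this note shows. Statements on the series, on what has been measured and on what is new or still open speak of the compounds shown alone.

Measured compounds:
- compound 1 `CC/N=C(\S)OC[C@H]1OC(n2cnc3c(NC4CCOC4)ncnc32)[C@H](O)[C@@H]1O`: in an assay on DDT1 cells (Cricetulus griseus) for binding affinity to adenosine receptor A1 (Homo sapiens), read by radioligand binding (on this read-out lower numbers stand for stronger inhibition and higher numbers for weaker inhibition), compound 1 gives 33 nM
- compound 2 `CCCNC(=O)OC[C@H]1OC(n2cnc3c(NC4CCOC4)ncnc32)[C@H](O)[C@@H]1O`: in this assay compound 2 gives 235 nM
- compound 3 `O[C@@H]1[C@@H](CO/C(S)=N/C2CC2)OC(n2cnc3c(NC4CCOC4)ncnc32)[C@@H]1O`: in this assay compound 3 gives 157 nM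

Compound 2 has the highest number of the three. One of its gaps is a 7.1-fold higher number from compound 1 to compound 2 (0.85 log units; beyond the scatter), beyond the scatter, whereas the other is a 1.5-fold lower number from compound 2 to compound 3 (0.18 log units; within the scatter), within the scatter.

Compound 4 `O=C(NC1CCC1)OC[C@H]1OC(n2cnc3c(NC4CCOC4)ncnc32)[C@H](O)[C@@H]1O` has not yet been measured in this assay. It differs from compound 2 by cyclobutyl in place of propyl on an amide-type nitrogen. Within the data shown here, no measured step changes a carbamate nitrogen substituent directly. The nearest comparison is the chain-to-ring change on the thioimidate nitrogen, a 4.8-fold higher number from compound 1 to compound 3 (0.68 log units; beyond the scatter), which weakened binding modestly. Compound 2 to compound 3 also exchanges chain for ring, but alongside a linker change, and stays within the scatter.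

On this basis a modest weakening, or no change beyond the scatter, is expected for compound 4; the expected step is a 1.9-fold higher number from compound 2 to compound 4 (0.28 log units; within the scatter). Compound 4 is therefore estimated at 450 nM, with a range from 130 nM to 1500 nM.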

Compound 4, inhibition constant: 306 nM
The estimate for compound 4 lay 1.5-fold (0.17 log units) above the measured number; low and high end bracket the measured number.
By their numbers in this assay, from the lowest: compound 1; then compounds 3, 2 and 4 (each within the scatter of the next).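

In this assay, among these compounds, cyclobutyl in place of propyl on the amide-type nitrogen gives the first direct reading at this position (a 1.3-fold higher number from compound 2 to compound 4 (0.11 log units; within the scatter)): here a chain-to-ring change stays within the scatter, while on the double-bonded nitrogen the ethyl-to-cyclopropyl change did not (a 4.8-fold higher number from compound 1 to compound 3 (0.68 log units; beyond the scatter)). The cyclobutyl carbamate also stays within the scatter of the cyclopropyl compound (a 1.9-fold higher number from compound 3 to compound 4 (0.29 log units; within the scatter)), and the gap from the ethyl compound remains beyond it (a 9.3-fold higher number from compound 1 to compound 4 (0.97 log units; beyond the scatter)), so compound 1 alone stands apart among the four. No measurement at hand accounts for these steps.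

Open, as far as these compounds go, is how much of the gap from compound 1 belongs to the linker and how much to the nitrogen substituent, for the two change together in each step to a carbamate. Also open, from the compounds shown here alone, is how a phenyl ring, a longer chain such as hexyl, or a carboxylic acid on the amide-type nitrogen would read.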